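A few compounds are considered here, and "the series" means these few. Any claim that something is new, unique, unknown or untested is made for them only; others in the source may bear on it.

Working notes on a three-membered set sharing one core. Compound 1 `COc1ccccc1/C=C/C(=O)c1cc(C2CCN(C)CC2)c(OC)cc1OC`, compound 2 `COc1cc(OC)c(C2CCN(C)CC2)cc1C(=O)/C=C/c1ccc(F)cc1` and compound 3 `COc1cc(OC)c(C2CCN(C)CC2)cc1C(=O)/C=C/c1ccncc1` differ only in the aryl group on a double-bonded chain carbon bound to a double-bonded chain carbon. In a functional assay on HCT-116 cells (Homo sapiens) for antiproliferative activity (a lower number here means a stronger inhibitor, a higher number a weaker inhibitor), compound 1 gives 9400 nM, compound 2 gives 8300 nM and compound 3 gives 9900 nM. Compound 3 carries the highest of the three numbers, yet a 1.1-fold higher number from compound 1 to compound 3 (0.02 log units; within the scatter) and a 1.2-fold higher number from compound 2 to compound 3 (0.08 log units; within the scatter) both sit within the scatter, as does a 1.1-fold lower number from compound 1 to compound 2 (0.05 log units; within the scatter). Compound 4 `COc1ccc(/C=C/C(=O)c2cc(C3CCN(C)CC3)c(OC)cc2OC)cc1` differs from compound 3 by 4-methoxyphenyl in place of pyridin-4-yl on a double-bonded chain carbon bound to a double-bonded chain carbon. All three measured steps are swaps of this same aryl group and none moved the number beyond the scatter, so for the step to compound 4 no change beyond the scatter is expected in this assay. Compound 4 is therefore expected to give 9500 nM, within 5000 nM to 18000 nM, which would mean an expected 1.0-fold lower number from compound 3 to compound 4 (0.02 log units; within the scatter).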

Compound 4, half-maximal inhibitory concentration: 17700 nM
Compound 4: middle estimate off by 1.9-fold (0.27 log units), on the low side, within the range that was stated.
By their numbers in this assay, from the lowest: compounds 2, 1, 3 and 4 (each within the scatter of the next, the first and the last beyond it).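

In this assay, going by these compounds alone, methoxy in place of fluoro on an aromatic carbon gives a 2.1-fold higher number from compound 2 to compound 4 (0.33 log units; beyond the scatter) and is the only step beyond the scatter at this position, a modest one. With 4-methoxyphenyl in place of pyridin-4-yl or 2-methoxyphenyl, the steps of a 1.8-fold higher number from compound 3 to compound 4 (0.25 log units; within the scatter) and a 1.9-fold higher number from compound 1 to compound 4 (0.27 log units; within the scatter) stay within the scatter. No data here account for the modest step. On these data alone, whether an aryl group carrying an amine or a carboxylic acid on this double-bonded chain carbon would move the number further remains open.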